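From chloro to fluoro on an aromatic carbon

The compounds below may be only part of what the source reports. "The series", "measured", "known", "first", "only" and "open" are said of these compounds alone.

Measured in an ADME assay on HEK-293T cells (Homo sapiens) for inhibition, read by CCK-8 assay, with a stated time of 48 h, tested at 20 uM; a lower number here means less inhibition of growth, a higher number more inhibition of growth at the concentration tested:
compound 1 `N#C/C(=C\c1ccccc1OS(=O)(=O)c1ccc(F)cc1)C(=O)Nc1nnc(Cc2cccc(F)c2)s1`: 17%
compound 2 `Cc1ccc(Cc2nnc(NC(=O)/C(C#N)=C/c3ccccc3OS(=O)(=O)c3ccc(Cl)cc3)s2)cc1`: 8%

Among the measured compounds shown here, compound 2 at 8% and compound 1 at 17% lie within the usual scatter of each other, so compound 2 cannot be told apart from the only other measured compound. For the measured compounds named here, the two structures differ in more than one place, and no measured pair isolates a single change.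

Compound 3 `Cc1ccc(Cc2nnc(NC(=O)/C(C#N)=C/c3ccccc3OS(=O)(=O)c3ccc(F)cc3)s2)cc1` departs from compound 2 in one place: fluoro in place of chloro on an aromatic carbon, with fluoro in place of chloro on an aromatic carbon, para to a large group. Compound 1, which also carries the (4-fluorophenyl)sulfonyl group, gives 17%. On that basis, no shift beyond the scatter is expected in this assay, and the estimated step is a number 4 percentage points higher from compound 2 to compound 3 (within the scatter). For compound 3 the expected value is 12%, within an estimated range of 2% to 24%.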

Compound 3, percent growth inhibition at one concentration: 11%
Beside the measured number, compound 3's estimate is 1 percentage points above it, within the range that was stated.
By their numbers in this assay, from the lowest: compounds 2, 3 and 1 (each within the scatter of the next).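

Fluoro in place of chloro on an aromatic carbon, para to a large group, gives a number 3 percentage points higher from compound 2 to compound 3 (within the scatter) in this assay; this pair isolates the change, and at this position it leaves the two compounds indistinguishable. Compound 3 also isolates a change at the other end of the molecule: 4-methylphenyl in place of 3-fluorophenyl on a saturated chain carbon bound to an aromatic carbon gives a number 6 percentage points lower from compound 1 to compound 3 (within the scatter), so neither single change separates its pair. No supporting evidence bears on these results.

The compounds shown test only two halogens at this position, so the effect of an amine, a methoxy group or a carboxylic acid there remains open. Whether either step would hold on another core is also unknown.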